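Working notes: ring-nitrogen substituent swap in a modulator series

The source may report more compounds than this note shows. Statements on the series, on what has been measured and on what is new or still open speak of the compounds shown alone.

Compound 1 `CC1CCCC(C(=O)N2CCc3nc(C#Cc4ccccc4)sc3C2)C1`: in an assay on HEK293 cells for positive allosteric modulation of metabotropic glutamate receptor 5 (Homo sapiens), read by FLIPR, with a stated time of 1 h (on this read-out lower numbers stand for an effect already at smaller amounts and higher numbers for an effect only at larger amounts of compound), compound 1 gives 100 nM
Compound 2 `CC(C)S(=O)(=O)N1CCc2nc(C#Cc3ccccc3)sc2C1`: in this assay compound 2 gives only a limit, > 10000 nM

Compound 2 stands at the edge of what this assay reports; its value is a limit, not a number, as the limit of > 10000 nM in this assay, at which 1 of the 2 values shown sits, states. Compound 3 `O=C(N1CCCCC1)N1CCc2nc(C#Cc3ccccc3)sc2C1` differs from compound 2 by (piperidin-1-yl)carbonyl in place of isopropylsulfonyl on an amine nitrogen in a ring. Going by the values given here, no measured step links these two. The expected change from compound 2 to compound 3 is an at least 16-fold lower number from compound 2 to compound 3 (1.22 log units; beyond the scatter), a gain beyond the scatter, because compound 1, which also carries a carbonyl-linked group on that amine nitrogen, gives 100 nM. Compound 3 is therefore estimated at 600 nM, with a range from 100 nM to 5000 nM.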

Compound 3, half-maximal effective concentration: 75 nM
The estimate for compound 3 lay 8.0-fold (0.90 log units) above the measured number, and the stated range ends above it.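

Replacing isopropylsulfonyl with (piperidin-1-yl)carbonyl on the amine nitrogen in a ring gives an at least 130-fold lower number from compound 2 to compound 3 (2.12 log units; beyond the scatter), so this position can separate a limit from a measured value. The value of compound 2 is a limit, not a number: the limit of > 10000 nM in this assay, at which 1 of the 3 values shown sits. Piperidin-1-yl in place of 3-methylcyclohexyl on the carbonyl carbon gives a 1.3-fold lower number from compound 1 to compound 3 (0.12 log units; within the scatter), so these two carbonyl-linked groups are not told apart.

The step from isopropylsulfonyl changes both the link and the group attached to it, leaving their shares open. Piperidin-1-ylsulfonyl or a small acetyl group at this nitrogen would bear on that question.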